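Amino to methoxy on a compound at the assay limit

The source may hold more compounds than are shown below. What is called first, only, known or untested is meant among the compounds shown, and "the series" means these compounds.

compound 1 `Nc1nc(N)c2c(-c3cccs3)cn([C@@H]3O[C@H](CO)[C@@H](O)[C@H]3O)c2n1`: > 100000 nM
compound 2 `Nc1nc(N)c2c(-c3ccsc3)cn([C@@H]3O[C@H](CO)[C@@H](O)[C@H]3O)c2n1`: > 100000 nM
compound 3 `Cc1nc(N)c2c(-c3cccs3)cn([C@@H]3O[C@H](CO)[C@@H](O)[C@H]3O)c2n1`: > 100000 nM

Compound 1 has no exact value in an ADME assay on BJ cells (Homo sapiens), read by MTT assay, with a stated time of 72 h; on this read-out lower numbers stand for stronger inhibition and higher numbers for weaker inhibition. Its entry of > 100000 nM is a limit of the assay and not a number. The whole set looks the same, with the limit of > 100000 nM in this assay, at which 3 of the 3 values shown sit. Where compound 1 stands can therefore be told only as that limit, and it cannot be ranked against the others.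

Compound 4 `COc1nc(N)nc2c1c(-c1cccs1)cn2[C@@H]1O[C@H](CO)[C@@H](O)[C@H]1O` has not yet been measured. It keeps the thiophen-2-yl group of compound 1 but carries methoxy in place of amino on an aromatic carbon.

The measured changes give no size to carry over. Methyl in place of amino gave a step that the two limits leave unreadable from compound 1 to compound 3, and that change touches the other amino group, not the one lost in compound 4. Thiophen-3-yl in place of thiophen-2-yl gave a step that the two limits leave unreadable from compound 1 to compound 2.

Compound 3 has also lost an amino group and still shows the limit > 100000 nM, so no step beyond the usual scatter is expected in this assay, and another limit is the likely result. The estimated step is a number no higher from compound 1 to compound 4 (the limit leaves the size open). For compound 4 the expected value is 100000 nM, with an estimated range of 30000 nM to 200000 nM.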

Compound 4, half-maximal inhibitory concentration: 99900 nM
For compound 4 the middle estimate is 1.0-fold (0.00 log units) above the measured one; low and high end bracket the measured number.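

Within the data shown here, compound 4 is the first in this set to give an actual number in this assay: compound 4 reads 99900 nM. Compound 1 has only a limit of the assay, > 100000 nM, and not a number. Methoxy in place of amino on this aromatic carbon, next to the ring nitrogen, therefore yields a readable value, but none of the steps among these compounds can be read in size, and the set as a whole remains close to one boundary: the limit of > 100000 nM in this assay, at which 3 of the 4 values shown sit.

Methoxy in place of amino at this position gives a number no higher from compound 1 to compound 4 (the limit leaves the size open), and the compounds shown leave open whether a different group here, such as ethoxy, dimethylamino or a chlorine atom, would give a clearly lower number or would return to the limit. Going by these compounds, it is also open whether methoxy would give a readable value when thiophen-3-yl, the group in compound 2, takes the place of thiophen-2-yl.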